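Replacing 2-amino-1,3-thiazol-5-yl with 2-oxoimidazolidin-1-yl

The source may report more compounds than this note shows. Statements on the series, on what has been measured and on what is new or still open speak of the compounds shown alone.

Compound 1 `CC(C)C(c1ccc(-c2ccc3cccc(F)c3c2)[nH]c1=O)N1CCCCC1=O`: 0.102 h
Compound 2 `CC(C)C(c1cnc(N)s1)c1ccc(-c2ccc3cccc(F)c3c2)[nH]c1=O`: 0.0983 h

Both values come from an ADME assay on microsomes from liver (Rattus norvegicus) for metabolic stability; on this read-out higher numbers stand for a longer-lived compound and lower numbers for a shorter-lived compound. Going by the values given here, with 0.0983 h, compound 2 lies within the scatter of compound 1, the only other compound measured so far. Compound 3 `CC(C)C(c1ccc(-c2ccc3cccc(F)c3c2)[nH]c1=O)N1CCNC1=O` has not yet been measured. It carries 2-oxoimidazolidin-1-yl in place of the 2-amino-1,3-thiazol-5-yl of compound 2, on a saturated chain carbon bound to an aromatic carbon and a saturated chain carbon: 2-oxoimidazolidin-1-yl in place of 2-amino-1,3-thiazol-5-yl on a saturated chain carbon bound to an aromatic carbon and a saturated chain carbon. Among the compounds with values here, one measured step bears on this change, at the same place: a 1.0-fold lower number from compound 1 to compound 2 (0.02 log units; within the scatter). This single step is thin evidence, and neither measured compound carries the entering group. Within the data shown here, with a 1.0-fold lower number from compound 1 to compound 2 (0.02 log units; within the scatter) as the only guide, no change beyond the scatter is expected in this assay. The expected step is a 1.1-fold higher number from compound 2 to compound 3 (0.05 log units; within the scatter). For compound 3 the estimated half-life is 0.11 h, with an expected range of 0.06 h to 0.22 h.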

Compound 3, half-life: 0.283 h
Compound 3: middle estimate off by 2.6-fold (0.41 log units), on the low side, and the stated range ends below it.
By their numbers in this assay, from the lowest: compounds 2 and 1 (each within the scatter of the next); then compound 3.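

In this assay, this place on a saturated chain carbon bound to an aromatic carbon and a saturated chain carbon proves able to shift the number, which the earlier exchange of groups had not shown. With 2-oxoimidazolidin-1-yl there is a 2.9-fold higher number from compound 2 to compound 3 (0.46 log units; beyond the scatter), and against the other earlier group, 2-oxopiperidin-1-yl, there is a 2.8-fold higher number from compound 1 to compound 3 (0.44 log units; beyond the scatter), so compound 3 stands clear of both compound 1 and compound 2. No measurement shown here accounts for this difference.

From the compounds shown here alone, it remains open whether the shift belongs to the 2-oxoimidazolidin-1-yl ring as a whole or to one part of it. A 2-oxopyrrolidin-1-yl group or an open-chain urea at the same place would help to tell these apart.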